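Nitro in place of bromo: expected cytotoxicity of compound 4

The source may hold more compounds than are shown below. What is called first, only, known or untested is meant among the compounds shown, and "the series" means these compounds.

Compound 1 `Brc1ccc(-c2nnc(Cn3nnc4ccccc43)o2)cc1` gives > 100000 nM in an ADME assay on cells (Macrophage, Homo sapiens) for inhibition; on this read-out higher numbers stand for lower toxicity in this test and lower numbers for higher toxicity in this test; this is a limit, not a number.
Compound 2 `Clc1cccc(-c2nnc(Cn3nnc4ccccc43)o2)c1` gives > 100000 nM in this assay; again a limit.
Compound 3 `Fc1cccc(-c2nnc(Cn3nnc4ccccc43)o2)c1` gives > 100000 nM in this assay, also a limit.

Compound 1 therefore stands only at a limit, as do the other two measured compounds. Compound 4 `O=[N+]([O-])c1ccc(-c2nnc(Cn3nnc4ccccc43)o2)cc1` differs from compound 1 by nitro in place of bromo on an aromatic carbon. The measured steps that bear on it, a step that the two limits leave unreadable from compound 1 to compound 2, a step that the two limits leave unreadable from compound 1 to compound 3 and a step that the two limits leave unreadable from compound 2 to compound 3, cannot be read in size, because of the limit of > 100000 nM in this assay, at which 3 of the 3 values shown sit. Within the data shown here, no measured step shows a halogen change moving the read-out off that limit, so compound 4 is expected to give 100000 nM, within 30000 nM to 300000 nM, most likely again as a limit, a step of a number no higher from compound 1 to compound 4 (the limit leaves the size open) being the estimate.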

Compound 4, half-maximal cytotoxic concentration: > 100000 nM
Compound 4 gave a limit, no number (the forecaster's own chance of this, stated with the estimate: 80%); the middle value lies on the limit itself.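

The step from compound 1 to compound 4 cannot be read in size, because both compounds stand at a limit: the limit of > 100000 nM in this assay, at which 4 of the 4 values shown sit.

The compounds shown leave open whether any change on the shared core would move the read-out in this assay off that limit.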